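A Ring Swap on the Piperidine Nitrogen

The source may report more compounds than this note shows. Statements on the series, on what has been measured and on what is new or still open speak of the compounds shown alone.

Three compounds share a core in which a partly saturated five-membered ring carrying an aromatic ring is joined to a carbonyl. Compound 1 `O=C(c1cscn1)N1CCC(C(=O)N2N=CC[C@H]2c2ccccc2)CC1` is the largest of them. Compound 2 `CC(C)(C)C(=O)N1N=CCC1c1cccnc1` and compound 3 `CC(C)(C)C(=O)N1N=CCC1c1cccc(F)c1` are smaller and carry a tert-butyl carbonyl instead. In a physicochemical assay for lipophilicity, read by HPLC, measured as chromatographic lipophilicity, at pH 7.4 (a lower number here means a more polar compound, a higher number a more lipophilic compound), compound 1 gives 3, which is the lowest of the three numbers. Compound 2 gives 3.2 in this assay, a number close enough to that of compound 1 that the two cannot be told apart. Compound 3 gives 5.9, well beyond the scatter from compound 1.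

Compound 4 `Cc1nnc(N2CCC(C(=O)N3N=CC[C@H]3c3ccccc3)CC2)o1` is not yet measured. It differs from compound 1 in a single place: 5-methyl-1,3,4-oxadiazol-2-yl in place of (1,3-thiazol-4-yl)carbonyl on an amine nitrogen in a ring. Going by the values given here, no pair of measured compounds shows this kind of change, so its effect has to be guessed from the structures alone. A modest step is expected, most likely downward, and it may well remain within the scatter. Compound 4 is therefore estimated at 2.7, with a range from 2 to 3.4, which would mean a step of a number 0.30 log units lower from compound 1 to compound 4 (within the scatter).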

Compound 4, distribution coefficient: 3.2
Beside the measured number, compound 4's estimate is 0.50 log units below it; the measured number falls inside the stated range.
By their numbers in this assay, from the lowest: compounds 1, 2 and 4 (each within the scatter of the next); then compound 3.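

In this assay, going by these compounds alone, replacing (1,3-thiazol-4-yl)carbonyl with 5-methyl-1,3,4-oxadiazol-2-yl on the amine nitrogen in the six-membered ring gives a number 0.20 log units higher from compound 1 to compound 4 (within the scatter) and is the first single-place step seen at this position. The two groups are not alike: the one that leaves contains sulfur and a carbonyl, while the one that enters has neither and carries three hetero atoms in its five-membered aromatic ring, yet the two compounds cannot be told apart on this read-out. Nothing on hand explains this outcome, so the result stands as an observation without a cause.

This single swap compares two neutral five-membered aromatic groups with the same count of hydrogen-bond acceptors and no hydrogen-bond donors, so it says little about how far the number can move at this position. From the compounds shown here alone, whether a carboxylic acid, a primary amine, a plain phenyl ring or a longer alkyl chain on the same nitrogen would stay within the scatter of compound 1 or move well beyond it remains open.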